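Amine substituent swaps on the shared core: cytotoxicity notes

The compounds below may be only part of what the source reports. "The series", "measured", "known", "first", "only" and "open" are said of these compounds alone.

Measured compounds:
compound 1 `N#CC1=C(N)N(c2ccc(S(N)(=O)=O)cc2)C2=C(C(=O)CCC2)C1c1ccc(Cl)cc1Cl` — 50%
compound 2 `C=CCNC(=S)NC1=C(C#N)C(c2ccc(Cl)cc2Cl)C2=C(CCCC2=O)N1c1ccc(S(N)(=O)=O)cc1` — 30%
compound 3 `N#CC1=C(NC(=S)Nc2ccc(Cl)cc2)N(c2ccc(S(N)(=O)=O)cc2)C2=C(C(=O)CCC2)C1c1ccc(Cl)cc1Cl` — 60%

In a functional assay on Ehrlich cells (Mus musculus) for cytotoxicity, read by trypan blue exclusion, with a stated time of 2 h, tested at 25 ug/mL (on this read-out higher numbers stand for a stronger effect at the one concentration tested and lower numbers for a weaker effect), compound 3 gives 60%, the highest of the three numbers. One step is a number 10 percentage points higher from compound 1 to compound 3 (within the scatter), so these two cannot be ordered. The other step is a number 30 percentage points higher from compound 2 to compound 3 (beyond the scatter).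

Compound 4 `N#CC1=C(NC(N)=O)N(c2ccc(S(N)(=O)=O)cc2)C2=C(C(=O)CCC2)C1c1ccc(Cl)cc1Cl` differs from compound 3 by a group of 3 heavy atoms (1 carbon, 1 nitrogen, 1 oxygen; no ring) in place of a group of 10 heavy atoms (7 carbon, 1 nitrogen, 1 sulfur, 1 chlorine; one six-membered aromatic ring of carbon only), on an amine nitrogen. Among the compounds with values here, two measured steps bear on this position: a number 10 percentage points higher from compound 1 to compound 3 (within the scatter) and a number 20 percentage points lower from compound 1 to compound 2 (beyond the scatter). A small group on this amine nitrogen thus ranged from no change to a modest drop. Compound 4 is expected to give 45%, between 25% and 65%. The expected step is a number 15 percentage points lower from compound 3 to compound 4 (beyond the scatter), a small decline that may not exceed the scatter.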

Compound 4, a percentage reported as activity, at one concentration (the size of the read-out at that concentration, not a potency): 35%
Estimate against measurement, compound 4: 10 percentage points above; measured number inside the range.
By their numbers in this assay, from the lowest: compounds 2 and 4 (each within the scatter of the next); then compounds 1 and 3 (each within the scatter of the next).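

Carbamoyl on this amine nitrogen gives a number 15 percentage points lower from compound 1 to compound 4 (beyond the scatter) in this assay, so a small group without a ring now joins the allyl-bearing group of compound 2 in falling beyond the scatter from the free amine. Against carbamoyl, the larger group of compound 3 holds up, with a number 25 percentage points lower from compound 3 to compound 4 (beyond the scatter) as the step, and compound 3 remains the exception to that drop. The other step, a number 5 percentage points higher from compound 2 to compound 4 (within the scatter) as printed, leaves carbamoyl and the allyl-bearing group unordered. No measurement offered here explains these differences.

Still open, on these data alone, is whether the 4-chlorophenyl ring alone carries the difference, which an acetyl or a 4-chlorophenylcarbamoyl group on this nitrogen would test.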